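The source may hold more compounds than are shown below. What is called first, only, known or untested is meant among the compounds shown, and "the series" means these compounds.

Measured in an ADME assay on a cell-free system (plasma, Homo sapiens) for protein binding:
Compound 1, `COCc1nc2nc(C)cc(Nc3ccc(C(F)(F)F)cc3)n2n1`: 75.6%
Compound 2, `CCc1nc2nc(C)cc(Nc3ccc(Cl)cc3)n2n1`: 86.1%
Compound 3, `COCc1nc2nc(C)cc(Nc3ccc(S(F)(F)(F)(F)F)cc3)n2n1`: 91.7%

Compound 1 shows the highest unbound fraction of the three. Compound 2 lies nearest to it, and the two values sit within the scatter of each other, so no order between them is claimed. Compound 3 is the furthest away; it differs from compound 1 only in the group on the aromatic carbon and shows a 2.9-fold lower unbound fraction from compound 1 to compound 3 (0.47 log units; beyond the scatter).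

Compound 4, `COCCc1nc2nc(C)cc(Nc3ccc(C(F)(F)F)cc3)n2n1`, awaits measurement. It differs from compound 1 by methoxymethyl in place of methoxy on a saturated chain carbon bound to an aromatic carbon. The group on the aromatic ring and the shared core are unchanged. Going by the values given here, no measured step covers a change of this kind: the single known step, from compound 1 to compound 3, alters the aromatic substituent and not the chain, so it gives no direct guide. The analyst therefore expects a step from compound 1 to compound 4 that stays within the scatter in this assay, in either direction. Compound 4 is expected to give 78%, with a range from 66% to 88%. The expected step is a 1.1-fold lower unbound fraction from compound 1 to compound 4 (0.04 log units; within the scatter).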

Compound 4, plasma protein binding: 73.7%
Compound 4: middle estimate off by 1.2-fold (0.08 log units) (unbound fraction), on the low side; low and high end bracket the measured number.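

In this assay, methoxymethyl in place of methoxy on a saturated chain carbon bound to an aromatic carbon gives a 1.1-fold higher unbound fraction from compound 1 to compound 4 (0.03 log units; within the scatter), so this one change at the chain leaves the read-out unresolved from that of the parent. Going by these compounds alone, the only earlier step from the same parent changed the group on the aromatic carbon instead and gave a 2.9-fold lower unbound fraction from compound 1 to compound 3 (0.47 log units; beyond the scatter), so the chain now has a measured step of its own, and it is the one that stays inside the scatter. Nothing at hand explains this result.

From the compounds shown here alone, whether a longer chain, an amine or a carboxylic acid at this place would move the unbound fraction beyond the scatter stays open. So does whether the same chain change would give a similar step with the aromatic group of compound 3.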